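The source may report more compounds than this note shows. Statements on the series, on what has been measured and on what is new or still open speak of the compounds shown alone.

Measured compounds:
compound 1 `O=[N+]([O-])c1cc(C[S+]([O-])c2nnnn2C2CCCCC2)cc([N+](=O)[O-])c1`, 23000 nM
compound 2 `O=[N+]([O-])c1cc(C[Se]c2nnnn2Cc2ccccc2)cc([N+](=O)[O-])c1`, 16500 nM

In an ADME assay on HepG2 cells (Homo sapiens) for cytotoxicity, read by MTT assay, with a stated time of 48 h (a lower number here means a stronger inhibitor, a higher number a weaker inhibitor), compound 2 gives 16500 nM. Going by the values given here, compound 1, which in this assay gives 23000 nM, stands within the usual scatter of compound 2, so the two cannot be told apart on these numbers, and no single step between them is defined, since they differ in two places at once.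

Compound 3 `O=[N+]([O-])c1cc(C[Se]c2nnnn2C2CCCCC2)cc([N+](=O)[O-])c1` has not been measured. It differs from compound 2 by cyclohexyl in place of benzyl on an aromatic nitrogen. Among the compounds with values here, the only other compound with a cyclohexyl on that nitrogen is compound 1, whose number lies close to that of compound 2, and nothing in the two measured values points to a shift beyond the scatter. Compound 3 is therefore expected to give about 18000 nM, with a likely range from 8000 nM to 40000 nM. That estimate means a step of a 1.1-fold higher number from compound 2 to compound 3 (0.04 log units; within the scatter), which is not expected to exceed the scatter.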

Compound 3, half-maximal inhibitory concentration: > 30000 nM
Compound 3 was reported as a limit; the forecaster's own chance of this, stated with the estimate: 10%; at least 1.6-fold (0.22 log units) between middle value and limit.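

In this assay compound 3 gives > 30000 nM, which is a limit and not a number. Cyclohexyl in place of benzyl on this aromatic nitrogen gives an at least 1.8-fold higher number from compound 2 to compound 3 (0.25 log units; that floor lies within the scatter), the first comparison shown that differs in this one place alone. Since that floor lies within the scatter, the change cannot be called one that goes beyond the scatter, and the step is bounded from one side only: the limit of > 30000 nM in this assay, at which 1 of the 3 values shown sits.

From the compounds shown here alone, how a phenyl set directly on that nitrogen, a longer chain such as hexyl, or an amine on the benzyl ring would read in this assay stays open. So does whether the same exchange of benzyl and cyclohexyl would read alike on the core of compound 1.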